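Nitro in place of 2-methoxyethoxy on a stilbene-like core

The compounds below may be only part of what the source reports. "The series", "measured", "known", "first", "only" and "open" are said of these compounds alone.

Measured compounds:
- compound 1, `COCCOc1cc(/C=C/c2ccc3ccccc3c2)ccc1OC`: 2990 nM
- compound 2, `COCCOc1cc(/C=C\c2ccc3ccccc3c2)ccc1OC`: 2990 nM

Compound 1 and compound 2 have the same atoms and bonds and differ only in the configuration of the double bond as drawn, E in compound 1 and Z in compound 2. In a functional assay on SK-MEL-28 cells (Homo sapiens) for inhibition (a higher number here means a weaker inhibitor, a lower number a stronger inhibitor), compound 1 gives 2990 nM, and compound 2 gives 2990 nM. The step of no change at the digits printed from compound 1 to compound 2 (within the scatter) lies within the scatter, which fits (the fact that compounds 1 and 2 differ only in the configuration as drawn). For the measured compounds named here, compound 1 therefore stands level with compound 2, the only other measured compound.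

Compound 3, `COc1ccc(/C=C/c2ccc3ccccc3c2)cc1[N+](=O)[O-]`, differs from compound 1 by nitro in place of 2-methoxyethoxy on an aromatic carbon. Going by the values given here, no measured step touches this part of the molecule; the only step known, no change at the digits printed from compound 1 to compound 2 (within the scatter), concerns the double bond alone and gives no guidance on replacing the 2-methoxyethoxy group with nitro. The expectation for compound 3 thus rests on compound 1 alone, with a wide range. Compound 3 is estimated at 3000 nM, between 700 nM and 13000 nM, which would mean an expected step of a 1.0-fold higher number from compound 1 to compound 3 (0.00 log units; within the scatter) in this assay.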

Compound 3, half-maximal inhibitory concentration: > 5000 nM
Compound 3 gave a limit, no number; the forecaster's own chance of this, stated with the estimate: 10%; at least 1.6-fold (0.22 log units) between middle value and limit.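

Compound 3 gives > 5000 nM in this assay, which is a limit of the assay and not a number. For the compounds shown here, the earlier pair spoke only to the configuration of the double bond, so nitro in place of 2-methoxyethoxy on an aromatic carbon, ortho to a methoxy group, is the first change seen at this position, and it gives an at least 1.6-fold higher number from compound 1 to compound 3 (0.22 log units; that floor lies within the scatter). The result shows that this exchange, which leaves 3 heavy atoms where there were 5 and keeps the count of hydrogen-bond acceptors, yields no lower number than compound 1, yet its floor does not establish a real loss, and the step is bounded on one side only: the limit of > 5000 nM in this assay, at which 1 of the 3 values shown sits.

The compounds shown leave open how far the true value of compound 3 lies from that of compound 1, and whether the double bond drawn Z would again match the E form once nitro is present. They also leave open how an amine, a carboxylic acid or a longer ether chain at the same aromatic carbon would read in this assay.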